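Replacing the nitro group of compound 2 with hydrogen

The source may report more compounds than this note shows. Statements on the series, on what has been measured and on what is new or still open speak of the compounds shown alone.

In an ADME assay on cells (Peritoneal macrophage, Mus musculus, strain BALB/c) for cytotoxicity, read by fluorescence and resazurin assay, with a stated time of 72 h (on this read-out higher numbers stand for lower toxicity in this test and lower numbers for higher toxicity in this test), compound 2 (`C/[N+]([O-])=C/c1ccc([N+](=O)[O-])s1`) gives 24200 nM and compound 1 (`O=[N+]([O-])c1ccc(/C=[N+](\[O-])Cc2ccccc2)s1`) gives 18500 nM as its value, so the two stand level within the scatter. Going to compound 3 (`C/[N+]([O-])=C/c1cccs1`) puts hydrogen in place of nitro on an aromatic carbon of the shared core. Going by the values given here, the only measured step (a 1.3-fold higher number from compound 1 to compound 2 (0.12 log units; within the scatter)) lies elsewhere and leaves the nitro untouched, so it gives no direct size for this change. The expected step (a 2.1-fold higher number from compound 2 to compound 3 (0.32 log units; beyond the scatter)) is therefore a loose estimate towards a higher number. The estimate for compound 3 in this assay is 50000 nM with an expected range of 15000 nM to 200000 nM for the measurement.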

Compound 3, half-maximal cytotoxic concentration: > 100000 nM
Compound 3: only a limit was reported; the forecaster's own chance of this, stated with the estimate: 20%; at least 2.0-fold (0.30 log units) between middle value and limit.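

In this assay, going by these compounds alone, hydrogen in place of nitro on an aromatic carbon, next to the ring sulfur, gives the first step beyond the scatter: an at least 4.1-fold higher number from compound 2 to compound 3 (0.61 log units; beyond the scatter). Compound 3 gives > 100000 nM, which is a limit of the assay, so the step has a lower bound but no fixed size. This position therefore moves the read-out, whereas the change on the chain carbon gave only a 1.3-fold higher number from compound 1 to compound 2 (0.12 log units; within the scatter).

From the compounds shown here alone, it remains open how an amine or a carboxylic acid at this position would read. Also open, going by these compounds, is whether the same change would give a similar step with the phenyl group of compound 1 present.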